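This account rests on a few compounds, and the source may have more. Where it says the series, first, only, none or still open, it means among the compounds named here.

Measured so far:
compound 1 `O=C(O)c1cc(-c2cccc(COc3ccc4c(=O)n(CC5CC5)sc4c3)c2)ccc1Cl` — 100%
compound 2 `CN(C)C(=O)c1cc(-c2cccc(COc3ccc4c(=O)n(C5CCCC5)sc4c3)c2)ccc1Cl` — 100%

In an ADME assay on a cell-free system (plasma, Rattus norvegicus) for metabolic stability, read by LC-MS, with a stated time of 1 h, at 37 degrees C, tested at 100 uM (on this read-out higher numbers stand for a more stable compound and lower numbers for a less stable compound), compound 1 gives 100% and compound 2 gives 100%; compound 1 stands level with compound 2, the two values lying within the scatter of each other. Going by the values given here, no step between measured compounds is available, so no direction has been set by the data. Compound 3 `O=C(O)c1cc(-c2cccc(COc3ccc4c(=O)n(C5CC5)sc4c3)c2)ccc1Cl` differs from compound 1 by cyclopropyl in place of cyclopropylmethyl on an aromatic nitrogen. Given that compound 1 reaches 100% in this assay, compound 3 is expected to remain near the top of the scale. The expected step is a number 3 percentage points lower from compound 1 to compound 3 (within the scatter), none beyond the scatter. Compound 3 is estimated at 97%, in the range 85% to 100%.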

Compound 3, percent of the compound remaining: 100%
Compound 3: middle estimate off by 3 percentage points, on the low side, and the stated range covers the measured number.
By their numbers in this assay, from the lowest: compounds 1, 2 and 3 (each within the scatter of the next).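

Cyclopropyl in place of cyclopropylmethyl on an aromatic nitrogen gives no change at the digits printed from compound 1 to compound 3 (within the scatter) in this assay and is the first one-place reading at this position, with the carboxylic acid held constant. Both groups are therefore tolerated here on this read-out, though a result this close to the top of the scale separates them poorly. No measurement on hand bears on a reason for this result.

Going by these compounds, it remains open whether a longer chain or an amine on this nitrogen would lower the percent remaining, and whether a methyl ester in place of the carboxylic acid would do so.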